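Building the urea of compound 3 from the amide of compound 2

The source may hold more compounds than are shown below. What is called first, only, known or untested is meant among the compounds shown, and "the series" means these compounds.

Compound 2 `COc1cc(-c2nn(-c3cccc(NC(=O)c4ccc(Cl)c(C(F)(F)F)c4)c3)cc2-c2ccncc2)ccc1Cl` is one of two measured members of the shared core. In a functional assay on MOLT-4 cells (Homo sapiens) for inhibition, read by sulforhodamine B assay, with a stated time of 48 h (a lower number here means that less compound is tolerated, a higher number that more compound is tolerated), compound 2 gives > 32500 nM, which is a limit of the assay and not a number. Compound 1 `COc1cc(-c2nn(-c3cccc(NC(=O)Nc4ccc(Cl)c(Cl)c4)c3)cc2-c2ccncc2)ccc1Cl` gives > 50000 nM in this assay, likewise a limit. The step that the two limits leave unreadable from compound 1 to compound 2 swaps (3,4-dichlorophenyl)amino for 4-chloro-3-(trifluoromethyl)phenyl on a carbonyl carbon, and its size cannot be read because the limit of > 32500 nM in this assay, at which 1 of the 2 values shown sits, and the limit of > 50000 nM in this assay, at which 1 of the 2 values shown sits, are where its two ends sit. Compound 3 `COc1cc(-c2nn(-c3cccc(NC(=O)Nc4ccc(Cl)c(C(F)(F)F)c4)c3)cc2-c2ccncc2)ccc1Cl` has not been measured. It differs from compound 2 by (4-chloro-3-(trifluoromethyl)phenyl)amino in place of 4-chloro-3-(trifluoromethyl)phenyl on a carbonyl carbon whose other neighbour is an amide-type nitrogen. Among the measured compounds shown here, the only measured step touches the same carbonyl carbon and is unreadable, so no movement beyond the scatter is expected in this assay. Compound 3 is therefore expected to remain at a limit, with a step that the limit leaves unreadable from compound 2 to compound 3 as the expected step. The estimate for compound 3 is 50000 nM, between 20000 nM and 120000 nM.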

Compound 3, concentration lethal to 50% of the cells: > 32500 nM
Compound 3: only a limit was reported; the forecaster's own chance of this, stated with the estimate: 75%; the middle value lies beyond the limit too.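

In this assay compound 3 gives > 32500 nM as a limit of the assay and not a number. Among the compounds shown here, no new step among compound 1, compound 2 and compound 3 can be read: the limit of > 32500 nM in this assay, at which 2 of the 3 values shown sit. The compounds shown leave open how far each lies past its limit, and whether either change moves the lethal concentration at all.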